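Working notes: 4-butylcyclohexyl in place of nitro

The compounds below may be only part of what the source reports. "The series", "measured", "known", "first", "only" and "open" are said of these compounds alone.

Measured so far in an ADME assay on Vero 76 cells (Chlorocebus sabaeus) for cytotoxicity, read by crystal violet staining, with a stated time of 96 h; a higher number here means that more compound is tolerated, a lower number that less compound is tolerated:
- compound 1 `FC(F)(F)c1cccc(NC(=S)Nc2ccc(I)cc2)c1`: 9500 nM
- compound 2 `FC(F)(F)c1cccc(NC(=S)Nc2ccc(Cl)cc2)c1`: 11000 nM
- compound 3 `O=[N+]([O-])c1ccc(NC(=S)Nc2cccc(C(F)(F)F)c2)cc1`: 10000 nM

All three values lie within the scatter of one another, so compound 3 (10000 nM) cannot be separated from the other two. The steps that reach it are a 1.1-fold higher number from compound 1 to compound 3 (0.02 log units; within the scatter) and a 1.1-fold lower number from compound 2 to compound 3 (0.04 log units; within the scatter).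

The next structure is compound 4 `CCCC[C@H]1CC[C@H](c2ccc(NC(=S)Nc3cccc(C(F)(F)F)c3)cc2)CC1`, which carries 4-butylcyclohexyl in place of nitro on an aromatic carbon, para to a large group: 4-butylcyclohexyl in place of nitro on an aromatic carbon.

The measured steps that bear on this change are those two exchanges together with a 1.2-fold higher number from compound 1 to compound 2 (0.06 log units; within the scatter). Each swaps one group for another on an aromatic carbon, and none goes beyond the scatter. None of them brings in a 4-butylcyclohexyl group or any non-aromatic ring, so they offer only a weak guide and the range has to stay wide. For the measured compounds named here, with no measured step pointing either way, the expectation in this assay is no step beyond the scatter (a 1.2-fold higher number from compound 3 to compound 4 (0.08 log units; within the scatter)). For compound 4 the estimated value is 12000 nM, with an expected range from 4000 nM to 40000 nM.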

Compound 4, half-maximal cytotoxic concentration: 17000 nM
The estimate for compound 4 lay 1.4-fold (0.15 log units) below the measured number, and the stated range covers the measured number.
By their numbers in this assay, from the lowest: compounds 1, 3, 2 and 4 (each within the scatter of the next).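

In this assay, the aromatic carbon para to a large group accepts 4-butylcyclohexyl with no step beyond the scatter, whether it is set against nitro (a 1.7-fold higher number from compound 3 to compound 4 (0.23 log units; within the scatter)), chloro (a 1.5-fold higher number from compound 2 to compound 4 (0.19 log units; within the scatter)) or iodo (a 1.8-fold higher number from compound 1 to compound 4 (0.25 log units; within the scatter)). The earlier compounds shown here covered only iodo, chloro and nitro here, whereas compound 4 brings in a group with one six-membered non-aromatic ring of carbon only, 2 defined stereocentres and 0 hydrogen-bond acceptors, and the four values still cannot be separated. Among these four compounds, neither the change from a single atom or nitro to this far larger group nor the loss of the nitro hydrogen-bond acceptors separates the values, and no measured evidence accounts for that reading.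

No group shown at this place moves the number beyond the scatter, so it remains open whether an amine, a carboxylic acid or a hydroxyl on the cyclohexyl ring would do so. On these data alone, the other stereoisomer of the 4-butylcyclohexyl group and a shorter chain on that ring also remain open, as does any replacement of the trifluoromethyl group shared by all four compounds.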